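Methyl shifted on the benzyl group: expectation for compound 4

A few compounds are considered here, and "the series" means these few. Any claim that something is new, unique, unknown or untested is made for them only; others in the source may bear on it.

Within the data shown here, compound 3 `Cc1cccc(CSc2cc(Cl)c(C)cc2S(=O)(=O)/N=C(\N)n2nc(C)cc2-c2ccccc2)c1` gives 105000 nM in a functional assay on MCF7 cells (Homo sapiens) for cytotoxicity, read by MTT assay, with a stated time of 72 h (a higher number here means a weaker inhibitor, a lower number a stronger inhibitor), the highest of the three numbers so far. Compound 1 `Cc1cc(-c2ccccc2)n(/C(N)=N/S(=O)(=O)c2cc(C)c(Cl)cc2SCc2ccccc2C(F)(F)F)n1` gives 101000 nM, and a 1.0-fold higher number from compound 1 to compound 3 (0.02 log units; within the scatter). Compound 2 `Cc1cc(-c2ccccc2)n(/C(N)=N/S(=O)(=O)c2cc(C)c(Cl)cc2SCc2ccc(C(F)(F)F)cc2)n1` gives 16000 nM; a 6.6-fold higher number from compound 2 to compound 3 (0.82 log units; beyond the scatter).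

Compound 4 `Cc1ccc(CSc2cc(Cl)c(C)cc2S(=O)(=O)/N=C(\N)n2nc(C)cc2-c2ccccc2)cc1` differs from compound 3 by 4-methylphenyl in place of 3-methylphenyl on a saturated chain carbon bound to a sulfur. Among the measured compounds shown here, two steps bear on this. In a 6.3-fold lower number from compound 1 to compound 2 (0.80 log units; beyond the scatter), 4-(trifluoromethyl)phenyl replaced 2-(trifluoromethyl)phenyl on the same saturated chain carbon bound to a sulfur, and in a 6.6-fold higher number from compound 2 to compound 3 (0.82 log units; beyond the scatter) the 4-substituted ring was the stronger one. A lower number is therefore expected for compound 4, of modest size, with a 3.5-fold lower number from compound 3 to compound 4 (0.54 log units; beyond the scatter). The estimate for compound 4 is 30000 nM, within a range of 10000 nM to 90000 nM.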

Compound 4, half-maximal inhibitory concentration: 89000 nM
Estimate against measurement, compound 4: 3.0-fold (0.47 log units) below; the measured number falls inside the stated range.
By their numbers in this assay, from the lowest: compound 2; then compounds 4, 1 and 3 (each within the scatter of the next).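

Shifting the methyl to give 4-methylphenyl leaves the number in this assay within the scatter (a 1.2-fold lower number from compound 3 to compound 4 (0.07 log units; within the scatter)), so a ring substituted in this way does not by itself reproduce the lower number of compound 2. Among these compounds, with the substitution pattern held, methyl in place of trifluoromethyl on an aromatic carbon is the first step that changes only the group (a 5.6-fold higher number from compound 2 to compound 4 (0.75 log units; beyond the scatter)), while 4-methylphenyl and 2-(trifluoromethyl)phenyl stay within the scatter (a 1.1-fold lower number from compound 1 to compound 4 (0.05 log units; within the scatter)). The data offer no evidence on why this is so.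

Open, as far as these compounds go, is whether 3-(trifluoromethyl)phenyl on the same saturated chain carbon bound to a sulfur would match compound 2. Also open, from the compounds shown here alone, is how 4-chlorophenyl or 4-methoxyphenyl would compare there.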